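The source may report more compounds than this note shows. Statements on the series, on what has been measured and on what is new or still open speak of the compounds shown alone.

Working notes on the series. Compound 1 `CC(C)n1ncc2c(C(=O)Nc3ccccc3F)cc(-c3cccnc3)nc21` is the starting point for the present step. In an ADME assay on LLC-MK2 cells (Macaca mulatta) for cytotoxicity, read by spectrophotometry and crystal violet staining, with a stated time of 4 days (on this read-out higher numbers stand for lower toxicity in this test and lower numbers for higher toxicity in this test), compound 1 gives 50000 nM. Compound 2 `CC(C)n1ncc2c(C(=O)N3CCc4cccnc43)cc(-c3cccs3)nc21` gives 50000 nM in this assay, level with compound 1 at the digits shown. Compound 3 `CNS(=O)(=O)c1cccc(NC(=O)c2cc(-c3cccs3)nc3c2cnn3C(C)C)c1` gives 25000 nM in this assay, a number that stays within the scatter of compound 1. The three measured compounds thus sit within the scatter of each other in this assay, and compound 1 has no gap beyond the scatter to either of the other two.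

The compound to be measured is compound 4 `CC(C)n1ncc2c(C(=O)Nc3ccccc3F)cc(-c3ccccc3)nc21`. It differs from compound 1 in one place: phenyl in place of pyridin-3-yl on an aromatic carbon. The change sits on an aromatic carbon of a six-membered aromatic ring with 1 nitrogen, part of a fused or bridged system of two rings; the amide and the rest of the shared core of compound 1 are unchanged. Among the compounds with values here, no step between two measured compounds maps this change, and none of the three measured numbers in this assay spreads beyond the scatter. The step of no change at the digits printed from compound 1 to compound 4 (within the scatter) is expected to stay within the scatter, with no direction favoured. Compound 4 is estimated at 50000 nM in this assay, with a range from 20000 nM to 100000 nM.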

Compound 4, half-maximal cytotoxic concentration: > 200000 nM
Compound 4 ended at the assay's limit (the forecaster's own chance of this, stated with the estimate: 40%); at least 4.0-fold (0.60 log units) between middle value and limit.
By their numbers in this assay, from the lowest: compounds 3, 1 and 2 (each within the scatter of the next). At a limit, above all of these: compound 4.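

In this assay compound 4 gives > 200000 nM, which is a limit of the assay and not a number. With this result the series holds its first step at this position and its first beyond the scatter, an at least 4.0-fold higher number from compound 1 to compound 4 (0.60 log units; beyond the scatter), with phenyl in place of pyridin-3-yl on an aromatic carbon next to the ring nitrogen and the amide and the rest of the shared core unchanged. This shows that the read-out in this test can respond to this single ring change, which the earlier compounds, all within the scatter of each other and linked by no step, could not show, but the full size of the step cannot be read: the limit of > 200000 nM in this assay, at which 1 of the 4 values shown sits.

As far as these compounds go, it remains open how this position reads with other groups, such as an amine or a carboxylic acid on the phenyl ring, or a small alkyl chain in place of the ring. From the compounds shown here alone, it is also open whether the same exchange gives a step of similar size when the amide differs from that of compound 1.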